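The source may report more compounds than this note shows. Statements on the series, on what has been measured and on what is new or still open speak of the compounds shown alone.

Compound 1 `COC1=CC(=O)c2ncsc2C1=O` stands in a functional assay on HepG2 cells (Homo sapiens) for cytotoxicity, read by MTT assay (on this read-out higher numbers stand for weaker inhibition and lower numbers for stronger inhibition), as "not tested" (no result reported). Two analogues of the shared core carry an arylamino group: compound 2 `CCOc1ccc(NC2=CC(=O)c3sc(C)nc3C2=O)cc1` gives 4.9 ug/mL, and compound 3 `O=C1C=C(Nc2ccc(Cl)cc2)C(=O)c2scnc21` gives 16.4 ug/mL. Of these two numbers, the number of compound 3 is the higher, and the gap to compound 2 is beyond the scatter. Compound 4 `O=C1C=C(Nc2ccccc2)C(=O)c2scnc21` is the next step: hydrogen in place of chloro on an aromatic carbon, on an aromatic carbon of a six-membered aromatic ring of carbon only, para to a large group. Among the measured compounds shown here, no step between two measured compounds isolates this change, so the expectation rests on compound 3 alone. Compound 4 is expected to give 20 ug/mL in this assay, between 8 ug/mL and 50 ug/mL, a step of a 1.2-fold higher number from compound 3 to compound 4 (0.09 log units; within the scatter) that is expected to stay within the scatter.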

Compound 4, half-maximal inhibitory concentration: 14.7 ug/mL
Estimate against measurement, compound 4: 1.4-fold (0.13 log units) above; measured number inside the range.
By their numbers in this assay, from the lowest: compound 2; then compounds 4 and 3 (each within the scatter of the next).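

In this assay, among the compounds shown here, the swap of chloro for hydrogen on an aromatic carbon, para to a large group, gives a 1.1-fold lower number from compound 3 to compound 4 (0.05 log units; within the scatter) and is the first single change that can be read here. At this position the chloro is thus not needed for the number that compound 3 gives, and its removal leaves the two compounds indistinguishable on this read-out. No measurement shown accounts for this outcome. Still open, from the compounds shown here alone, is how a methoxy group, an amine or a carboxylic acid would read at this same place. Whether any of them would move the number beyond the scatter also remains unanswered.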